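Compound 4: Phenyl in Place of 4-Cyanophenyl

The compounds below may be only part of what the source reports. "The series", "measured", "known", "first", "only" and "open" are said of these compounds alone.

The three measured compounds share the core of compound 1 `Cc1nnc(SCC(=O)N/N=c2/scc(-c3ccc(C#N)cc3)n2-c2ccccc2)s1`, which in a functional assay on C6 cells (Rattus norvegicus) for cytotoxicity, read by MTT assay, with a stated time of 24 h (a higher number here means a weaker inhibitor, a lower number a stronger inhibitor), has no reported result ("not determined" (no result reported)). Compound 2 `Cn1cnnc1SCC(=O)N/N=c1/scc(-c2ccc(C#N)cc2)n1-c1ccccc1` is the starting point here. In this assay compound 2 gives only a limit of the assay, > 200 ug/mL, and no single number. Compound 3 `Cn1nnnc1SCC(=O)N/N=c1/scc(-c2ccc(C#N)cc2)n1-c1ccccc1` gives 23.3 ug/mL in this assay. For the measured compounds named here, the single measured step, an at least 8.5-fold lower number from compound 2 to compound 3 (0.93 log units; beyond the scatter), rests on the limit of compound 2 (the limit of > 200 ug/mL in this assay, at which 1 of the 3 values shown sits). Compound 4 `Cn1cnnc1SCC(=O)N/N=c1/scc(-c2ccccc2)n1-c1ccccc1` differs from compound 2 by hydrogen in place of cyano on an aromatic carbon, read one bond further out as 4-cyanophenyl to phenyl. Going by the values given here, no measured step touches this position: the one step known changes only the heterocycle on the sulfur and keeps the 4-cyanophenyl. With compound 2 sitting at the limit, the direction of the step cannot be read from the data, and a weak result is expected again. The estimate for compound 4 in this assay is 200 ug/mL, ranging from 60 ug/mL to 600 ug/mL. This expectation amounts to a number no higher from compound 2 to compound 4 (the limit leaves the size open).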

Compound 4, half-maximal inhibitory concentration: 68.3 ug/mL
Beside the measured number, compound 4's estimate is 2.9-fold (0.47 log units) above it; low and high end bracket the measured number.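

In this assay, taking the cyano off the 4-cyanophenyl group gives an at least 2.9-fold lower number from compound 2 to compound 4 (0.46 log units; beyond the scatter), so this position, which the earlier step left untouched, does bear on the read-out. Together with the change on the sulfur, it is now the second single change shown to bring a measurable number out of the same starting compound, and the nitrile is not needed for that number to appear. How large the step really is stays unknown, since compound 2 is recorded only as a limit of the assay: the limit of > 200 ug/mL in this assay, at which 1 of the 4 values shown sits.

On these data alone, what an amine, a methoxy group or a carboxylic acid would do in place of the cyano stays open. So does whether the same change would lower the number with 1-methyl-1H-tetrazol-5-yl on the sulfur.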